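Removing the chloro from compound 1: expected small step

This account rests on a few compounds, and the source may have more. Where it says the series, first, only, none or still open, it means among the compounds named here.

Two members of the series carry a reading in a functional assay on CNE-2 cells (Homo sapiens) for cytotoxicity, read by MTT assay, with a stated time of 72 h; on this read-out higher numbers stand for weaker inhibition and lower numbers for stronger inhibition. Compound 1 `COc1cc2ncnc(NNC(=S)NC(=O)c3ccccc3Cl)c2cc1OC` gives 9670 nM in this assay and stands as the highest of the two numbers shown. Compound 2 `O=C(NC(=S)NNc1ncnc2ccccc12)c1ccc(F)cc1` gives 2840 nM in this assay, a lower number lying beyond the scatter. The two structures differ from each other in more than one place, so that gap is not read as the work of any single change.

Compound 3 `COc1cc2ncnc(NNC(=S)NC(=O)c3ccccc3)c2cc1OC` is compound 1 with one change: hydrogen in place of chloro on an aromatic carbon, ortho to a large group. Within the data shown here, no measured pair isolates this change, so there is no step to lean on; compound 2 is no guide here, as it alters the core substitution as well.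

Without such a step, the expected step is a 1.2-fold lower number from compound 1 to compound 3 (0.08 log units; within the scatter), that is, none beyond the scatter, with no direction preferred. The estimate for compound 3 in this assay is 8000 nM, with a range from 3000 nM to 22000 nM.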

Compound 3, half-maximal inhibitory concentration: 8180 nM
For compound 3 the middle estimate is 1.0-fold (0.01 log units) below the measured one, and the stated range covers the measured number.
By their numbers in this assay, from the lowest: compound 2; then compounds 3 and 1 (each within the scatter of the next).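

In this assay, among these compounds, hydrogen in place of chloro on an aromatic carbon, ortho to a large group, gives a 1.2-fold lower number from compound 1 to compound 3 (0.07 log units; within the scatter) and provides the first reading of a change in one place. With the rest of the structure held constant, the 2-chlorophenyl and phenyl forms cannot be told apart in this assay, so the chloro at this position is not required for the reading seen with compound 1. Nothing at hand bears on the reason for this result.

The compounds shown leave open whether the position stays equally flat with a methoxy, an amine or a carboxylic acid in place of the chloro, since the only two substituents compared here are chloro and hydrogen. As far as these compounds go, compound 2 differs from compound 3 in more than one place, so it remains open which of its differences accounts for its reading in this assay and whether the core substitution or the fluoro on the benzoyl ring carries it.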